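The source may report more compounds than this note shows. Statements on the series, on what has been measured and on what is new or still open speak of the compounds shown alone.

The shared core of compound 1 `N[C@H]1CC[C@H](Nc2c(C(=O)NCc3ccc(Oc4ccccc4)cc3)nc(Br)c3cccnc23)CC1` carries an amide to a benzyl group bearing a phenoxy substituent and, on the other side, an amine that ends in a primary amine. In a functional assay on SK-BR-3 cells (Homo sapiens) for cytotoxicity, read by MTT assay, with a stated time of 72 h (on this read-out higher numbers stand for weaker inhibition and lower numbers for stronger inhibition), compound 1 gives "not determined" (no result reported), so no number stands for it here. Two relatives do have results. Compound 2 `Nc1ccc(Nc2c(C(=O)NCc3ccc(F)cc3)nc(Br)c3cccnc23)cc1` gives 4000 nM in this assay. Compound 3 `NCCCNc1c(C(=O)NCc2ccc(F)cc2)ncc2cccnc12`, which carries a short chain amine instead of a ring amine, gives > 10000 nM in this assay, and this is a limit of the assay rather than a number; it is the limit of > 10000 nM in this assay, at which 1 of the 3 values shown sits.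

Compound 4 `COc1ccc(CNC(=O)c2nc(Br)c3cccnc3c2N[C@H]2CC[C@H](N)CC2)cc1` differs from compound 1 in one place: methyl in place of phenyl on an oxygen on an aromatic ring. Among the compounds with values here, because nothing has been measured for compound 1 itself, no step in this assay can be drawn for this change, and the two compounds that were measured share only the core and the amide with compound 4. Seen against compound 2 with 4000 nM, the expected result is weak inhibition. The result of compound 3 is a limit of the assay and points the same way. Compound 4 is estimated at 5000 nM, within a range from 1500 nM to 15000 nM.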

Compound 4, half-maximal inhibitory concentration: 5000 nM
Estimate against measurement, compound 4: no gap at the digits printed; low and high end bracket the measured number.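

No step can be read between compound 1 and compound 4: compound 1 has no number in this assay. The compounds shown leave open what the change from phenoxy to methoxy does to the result in this assay, and nothing shown accounts for the value of compound 4.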